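Swapping an Aryl Group: Expected Permeability of Compound 4

A few compounds are considered here, and "the series" means these few. Any claim that something is new, unique, unknown or untested is made for them only; others in the source may bear on it.

Measured compounds:
- compound 1 `Cc1ccc(C)c(-c2nc(CN3CCC(C(=O)NCCCN4C[C@H](C)C[C@H](C)C4)CC3)c(C)o2)c1`: "not determined" (no result reported)
- compound 2 `Cc1ccccc1-c1nc(CN2CCC(C(=O)NCCCN3CCC(C)CC3)CC2)c(C)o1`: 425 10^-6 cm/s
- compound 3 `Cc1ccccc1-c1nc(CN2CCC(C(=O)NCCCN3CCCC(CC(C)C)C3)CC2)c(C)o1`: 3 10^-6 cm/s

All three compounds share one core. In a physicochemical assay for permeability, using PAMPA (a lower number here means that the compound crosses the layer more slowly, a higher number that the compound crosses the layer faster), compound 1 gives "not determined" (no result reported), so compound 1 stands nowhere on the scale: there is no single number for it. Compound 2 gives 425 10^-6 cm/s in this assay, and compound 3 gives 3 10^-6 cm/s. Going by the values given here, the only step that is measured, a 140-fold lower number from compound 2 to compound 3 (2.15 log units; beyond the scatter), concerns a group of 10 heavy atoms in place of a group of 7 heavy atoms on a saturated chain carbon, three bonds along the chain from an amide-type nitrogen.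

Compound 4 `Cc1oc(-c2c(Br)cccc2Br)nc1CN1CCC(C(=O)NCCCN2C[C@H](C)C[C@H](C)C2)CC1` differs from compound 1 at another place: 2,6-dibromophenyl in place of 2,5-dimethylphenyl on an aromatic carbon

Among the compounds with values here, no measured step touches the aromatic carbon of the five-membered ring where this change sits, so the measured steps do not bear directly on it. Because the step of a 140-fold lower number from compound 2 to compound 3 (2.15 log units; beyond the scatter) shows how widely compounds of this core can spread in this assay, the expected number for compound 4 is uncertain and is set near the middle of the spread. Compound 4 is estimated at 40 10^-6 cm/s, with an expected range from 3 10^-6 cm/s to 400 10^-6 cm/s.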

Compound 4, apparent permeability: < 1 10^-6 cm/s
Compound 4: only a limit was reported; the forecaster's own chance of this, stated with the estimate: 5%; middle value at least 40-fold (1.60 log units) away from the limit.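

In this assay, compound 4 gives < 1 10^-6 cm/s, which is a limit and not a number. Going by these compounds alone, with no single number for compound 1 in this assay, no step from compound 1 to compound 4 can be read. The compounds shown leave open how far 2,6-dibromophenyl in place of 2,5-dimethylphenyl moves the apparent permeability on the shared core.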